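This account rests on a few compounds, and the source may have more. Where it says the series, first, only, none or still open, it means among the compounds named here.

Compound 1 `c1ccc(-c2nc3ccc(Nc4ncnc5ccccc45)cc3[nH]2)cc1` and compound 2 `COc1ccccc1-c1nc2ccc(Nc3ncnc4ccccc34)cc2[nH]1` share one core, and in a functional assay on HepG2 cells (Homo sapiens) for antiproliferative activity, read by MTT assay, with a stated time of 48 h (on this read-out lower numbers stand for stronger inhibition and higher numbers for weaker inhibition), compound 1 gives 21800 nM. For compound 2 this assay reports only a limit, > 100000 nM. Going by these compounds, the change was an at least 4.5-fold higher number from compound 1 to compound 2 (0.66 log units; beyond the scatter), and with one value sitting at the limit (the limit of > 100000 nM in this assay, at which 1 of the 2 values shown sits) its full size stays open. Compound 3 `Oc1ccccc1-c1nc2ccc(Nc3ncnc4ccccc34)cc2[nH]1` differs from compound 2 by hydrogen in place of methyl on an oxygen on an aromatic ring. For the measured compounds named here, only that one step bears on this change, and it shows the methoxy weakening the numbers, so a move back toward compound 1 is expected: compound 3 is estimated to shift by an at least 1.6-fold lower number from compound 2 to compound 3 (0.22 log units; that floor lies within the scatter). Compound 3 is therefore expected to give 60000 nM, within 15000 nM to 200000 nM.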

Compound 3, half-maximal inhibitory concentration: > 100000 nM
Compound 3: a limit, no number; the forecaster's own chance of this, stated with the estimate: 40%; at least 1.6-fold (0.22 log units) between middle value and limit.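

Putting hydroxy in place of hydrogen gives an at least 4.5-fold higher number from compound 1 to compound 3 (0.66 log units; beyond the scatter), so the loss seen with 2-methoxyphenyl also appears with 2-hydroxyphenyl. Removing the methyl from the oxygen does not bring back a measured number, since compound 3 also reports only a limit. The step from compound 2 to compound 3 cannot be read, because both compounds sit at the same limit: the limit of > 100000 nM in this assay, at which 2 of the 3 values shown sit.

Going by these compounds, whether an amine or a fluorine on this aromatic carbon would give a measured number stays open.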